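The source may hold more compounds than are shown below. What is called first, only, known or untested is meant among the compounds shown, and "the series" means these compounds.

In an ADME assay on L02 cells (Homo sapiens) for cytotoxicity, read by MTT assay, with a stated time of 24 h (on this read-out lower numbers stand for stronger inhibition and higher numbers for weaker inhibition), two compounds sharing one core have been measured so far. Compound 1 `COc1cc(/C=C2\CN(C)C/C(=C\c3ccc(F)cc3)C2=O)cc(OC)c1` gives 21900 nM, and compound 2 `COc1cc(/C=C2\CN(C)C/C(=C\c3ccc(Br)cc3)C2=O)cc(OC)c1` gives 21300 nM. Among the measured compounds shown here, compound 2 therefore stands level with compound 1, the only other compound available for comparison. For the measured compounds named here, the single measured step, a 1.0-fold lower number from compound 1 to compound 2 (0.01 log units; within the scatter), lies within the scatter of repeated measurements.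

Compound 3 `COc1cc(/C=C2\CN(C)C/C(=C\c3ccc(Br)cc3)C2=O)cc(OC)c1OC` differs from compound 2 in one place: methoxy in place of hydrogen on an aromatic carbon. This is methoxy in place of hydrogen on an aromatic carbon, ortho to two methoxy groups and para to a large group.

The measured step bears on this change only loosely, since it exchanged fluoro for bromo and added no methoxy group. Going by the values given here, with compound 2 at 21300 nM as the starting point and a 1.0-fold lower number from compound 1 to compound 2 (0.01 log units; within the scatter) as the only guide, no step beyond the scatter is expected in this assay, and neither direction can be favoured. The expected step is a 1.1-fold lower number from compound 2 to compound 3 (0.03 log units; within the scatter). For compound 3 the estimated value is 20000 nM, with an expected range from 8000 nM to 45000 nM.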

Compound 3, half-maximal inhibitory concentration: 15400 nM
The estimate for compound 3 lay 1.3-fold (0.11 log units) above the measured number; the range from low to high includes it.
By their numbers in this assay, from the lowest: compounds 3, 2 and 1 (each within the scatter of the next).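

In this assay the step for methoxy in place of hydrogen on an aromatic carbon, ortho to two methoxy groups and para to a large group, is a 1.4-fold lower number from compound 2 to compound 3 (0.14 log units; within the scatter) and so cannot be told apart from repeat-to-repeat variation. Among the compounds shown here, the earlier step exchanged only fluoro for bromo on the other aromatic ring, so this is the first view of a change on the ring that carries the methoxy groups, and here too a single change leaves the read-out within the scatter. Nothing available explains the size of this step or links it to any property of the methoxy group.

The compounds shown leave open whether a different group at this position, such as an amine, a carboxylic acid or a longer chain like butoxy, would give a step beyond the scatter. They also leave open whether the same methoxy addition would give a similar step with fluoro in place of bromo on the other ring.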